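From 2-hydroxybutyl to 2-acetoxybutyl

A few compounds are considered here, and "the series" means these few. Any claim that something is new, unique, unknown or untested is made for them only; others in the source may bear on it.

In a functional assay on DU-145 cells (Homo sapiens) for cytotoxicity, read by MTT assay (on this read-out lower numbers stand for stronger inhibition and higher numbers for weaker inhibition), compound 1 `CC(C)=CC[C@@H](OC(=O)c1ccco1)C1=CC(=O)c2c(O)ccc(O)c2C1=O` is reported only as a limit, > 100000 nM. Among the measured compounds shown here, compound 2 `CCC(O)CO[C@H](CC=C(C)C)C1=CC(=O)c2c(O)ccc(O)c2C1=O` gives 16400 nM, the only actual number so far. Compound 3 `CCC(CO[C@H](CC=C(C)C)C1=CC(=O)c2c(O)ccc(O)c2C1=O)OC(C)=O` differs from compound 2 by acetyl in place of hydrogen on an oxygen on a saturated carbon, turning 2-hydroxybutyl into 2-acetoxybutyl. For the measured compounds named here, the one measured step, an at least 6.0-fold lower number from compound 1 to compound 2 (0.78 log units; beyond the scatter), exchanges a whole group and rests on a limit, so it bears only loosely on this change. In this assay no step beyond the scatter is expected, with a slight lean towards a higher number: a 1.3-fold higher number from compound 2 to compound 3 (0.13 log units; within the scatter). The estimate for compound 3 is 22000 nM, with an expected range of 6000 nM to 70000 nM.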

Compound 3, half-maximal inhibitory concentration: 25400 nM
Estimate against measurement, compound 3: 1.2-fold (0.06 log units) below; the measured number falls inside the stated range.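

In this assay, hydroxy and acetoxy on this saturated carbon cannot be told apart, a 1.5-fold higher number from compound 2 to compound 3 (0.19 log units; within the scatter), so a free hydroxy is not needed for a measurable number in this pair. Like 2-hydroxybutyl, 2-acetoxybutyl stands clear of (furan-2-yl)carbonyl at this oxygen, an at least 3.9-fold lower number from compound 1 to compound 3 (0.59 log units; beyond the scatter). Compound 1 is held only as a limit: the limit of > 100000 nM in this assay, at which 1 of the 3 values shown sits.

Going by these compounds, whether an amine or a carboxylic acid on the butyl chain, or a longer chain in its place, would move the number beyond the scatter remains open.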